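The source may hold more compounds than are shown below. What is called first, only, known or untested is meant among the compounds shown, and "the series" means these compounds.

Measured so far:
Compound 1 `C=C/C(C)=C/CC/C(C)=C/c1cc(C(=O)O)co1`: 39800 nM
Compound 2 `C=C/C(C)=C\CC/C(C)=C/c1cc(C(=O)OC)co1`: 51400 nM

Both compounds were tested in a functional assay on THP-1 cells (Homo sapiens) for cytotoxicity, read by MTT assay, with a stated time of 48 h; a lower number here means a stronger inhibitor, a higher number a weaker inhibitor. Going by the values given here, there, compound 2 gives 51400 nM, and this value lies within the scatter of the only other number available, that of compound 1 at 39800 nM. Compound 2 therefore stands level with compound 1 on these data.

The next compound, compound 3 `C=C/C(C)=C/CC/C(C)=C/c1cc(C(=O)OC)co1`, has not yet been measured. Its relation to compound 2 is purely one of geometry: the two compounds have the same atoms and bonds and differ only in configuration as drawn: 1 of 2 stereo elements differ; a double bond is drawn Z in compound 2 and E in compound 3. Nothing enters or leaves, and one double bond is drawn Z in compound 2 and E in compound 3.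

Among the compounds with values here, no measured pair shows what such a change does in this assay, so no step beyond the scatter is expected, in either direction. The expected change is small, an estimated 1.1-fold lower number from compound 2 to compound 3 (0.04 log units; within the scatter). For compound 3 the estimated value is 47000 nM, with an expected range of 24000 nM to 90000 nM.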

Compound 3, half-maximal inhibitory concentration: 25800 nM
Compound 3: the middle estimate sits 1.8-fold (0.26 log units) above what was measured; measured number inside the range.
By their numbers in this assay, from the lowest: compounds 3, 1 and 2 (each within the scatter of the next).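

In this assay, a change of double-bond geometry now has a measured pair behind it, and that pair shows a 2.0-fold lower number from compound 2 to compound 3 (0.30 log units; within the scatter), so on these data the geometry does not separate the two compounds. The change of methyl in place of hydrogen on an oxygen next to a carbonyl group, now read with both double bonds drawn alike, gives a 1.5-fold lower number from compound 1 to compound 3 (0.19 log units; within the scatter), so it does not separate its two compounds either. Any reading of the geometry step rests on a single difference: the fact that compounds 2 and 3 differ only in the configuration as drawn.

The compounds shown leave open whether an amide, or a longer chain in place of that methyl, would give a step beyond the scatter in this assay. They also leave open what a change of geometry at the other double bond would do there.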